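The source may report more compounds than this note shows. Statements on the series, on what has been measured and on what is new or still open speak of the compounds shown alone.

Working notes on the series. Compound 1 `CC(C)(C)C/N=C(\NC#N)Nc1ccncc1` is the reference point; in a functional assay on the whole organism (blood, strain Wistar-Okamoto) with Rattus norvegicus as the target, with a stated time of 5 days (a lower number here means that less compound is needed, a higher number that more compound is needed for the effect), compound 1 gives 5 mg/kg. Compound 2 `CCC(/N=C(\NC#N)Nc1ccncc1)C(C)C` carries 1-isopropylpropyl where compound 1 carries neopentyl, and in this assay compound 2 gives 5 mg/kg. Going by the values given here, the step of no change at the digits printed from compound 1 to compound 2 (within the scatter) is the only measured step so far, and it left the read-out where it was, so compound 2 stands level with compound 1 and nothing in the numbers separates them.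

Compound 3 `N#CN/C(=N\C1CCCCC1)Nc1ccncc1` is the next step. Its change from compound 2 is cyclohexyl in place of 1-isopropylpropyl on a double-bonded nitrogen. Among the compounds with values here, only one measured step bears on this, the exchange from compound 1 to compound 2 on the same double-bonded nitrogen, which stayed within the scatter while the branched chain was reshaped; the cyclohexyl of compound 3 again keeps the count of carbon unchanged. The expected step of no change at the digits printed from compound 2 to compound 3 (within the scatter) is therefore none beyond the scatter. Compound 3 is estimated at 5 mg/kg, with a range from 2.5 mg/kg to 10 mg/kg.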

Compound 3, minimum effective dose: 20 mg/kg
Compound 3: the middle estimate sits 4.0-fold (0.60 log units) below what was measured, and the stated range ends below it.
By their numbers in this assay, from the lowest: compounds 1 and 2 (each within the scatter of the next); then compound 3.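

In this assay the group on the double-bonded nitrogen turns out not to be interchangeable: the earlier exchange between two open chains stayed within the scatter, whereas cyclohexyl, with its six carbons held in a non-aromatic ring, gives a 4.0-fold higher number from compound 2 to compound 3 (0.60 log units; beyond the scatter) and also a 4.0-fold higher number from compound 1 to compound 3 (0.60 log units; beyond the scatter) in the same direction. Both open-chain groups, neopentyl and 1-isopropylpropyl, thus stand apart from cyclohexyl, so among these three compounds the read-out follows the presence of the ring and not the count of heavy atoms. Nothing at hand says what lies behind this step.

On these data alone, whether the higher number belongs to any ring here or to this ring size stays open, and a cyclopentyl or cycloheptyl group on the same nitrogen would address that. Also open, as far as these compounds go, is how a cyclohexyl ring carrying a hydroxyl group would read.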